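This account rests on a few compounds, and the source may have more. Where it says the series, first, only, none or still open, it means among the compounds named here.

Measured in an ADME assay on Akata cells (Homo sapiens) for cytotoxicity; a higher number here means that more compound is tolerated, a lower number that less compound is tolerated:
- compound 1 `Nc1nc2c(ncn2/C=C2\C[C@@H]2[C@H](O)CO)c(=O)[nH]1`: 67000 nM
- compound 2 `Nc1nc2c(ncn2/C=C2/C[C@@H]2[C@@H](O)CO)c(=O)[nH]1`: 56000 nM
- compound 3 `Nc1nc2c(ncn2/C=C2/C[C@H]2[C@H](O)CO)c(=O)[nH]1`: 62600 nM

All three compounds sit level, so compound 3 has no real rank among them. The steps that reach it, a 1.1-fold lower number from compound 1 to compound 3 (0.03 log units; within the scatter) and a 1.1-fold higher number from compound 2 to compound 3 (0.05 log units; within the scatter), show this.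

The next compound is compound 4 `Nc1nc2c(ncn2/C=C2\C[C@H]2[C@@H](O)CO)c(=O)[nH]1`, which is compared here with compound 3: the two compounds have the same atoms and bonds and differ only in configuration as drawn: 2 of 3 stereo elements differ; a stereocentre at a saturated chain carbon is drawn S in compound 3 and R in compound 4; a double bond is drawn Z in compound 3 and E in compound 4. No atoms change, only the way the same atoms are arranged in space.

Among the compounds with values here, three measured steps bear on this, since each also changes two stereo elements and nothing else. The closest parallel is a 1.2-fold lower number from compound 1 to compound 2 (0.08 log units; within the scatter), which also alters a stereocentre at a saturated chain carbon together with the double bond. The other two are a 1.1-fold lower number from compound 1 to compound 3 (0.03 log units; within the scatter) and a 1.1-fold higher number from compound 2 to compound 3 (0.05 log units; within the scatter). As none of these rises above the scatter, no real shift in either direction is expected in this assay.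

The expected change is a 1.0-fold lower number from compound 3 to compound 4 (0.00 log units; within the scatter).

For compound 4 the estimated value is 62000 nM, with an expected range from 42000 nM to 92000 nM.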

Compound 4, half-maximal cytotoxic concentration: 75000 nM
For compound 4 the middle estimate is 1.2-fold (0.08 log units) below the measured one, and the stated range covers the measured number.
By their numbers in this assay, from the lowest: compounds 2, 3, 1 and 4 (each within the scatter of the next).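

Compound 4 adds a fourth arrangement of the same atoms, and in this assay it stays level with the other three (a 1.2-fold higher number from compound 3 to compound 4 (0.08 log units; within the scatter); a 1.3-fold higher number from compound 2 to compound 4 (0.13 log units; within the scatter); a 1.1-fold higher number from compound 1 to compound 4 (0.05 log units; within the scatter)). The earlier steps shown here that changed the double bond all ran from E to Z, whereas the steps reaching compound 4 from compound 2 and compound 3 run from Z to E, and they too stay within the scatter. Among these four compounds, then, neither direction of the double bond change, paired with a change at either stereocentre, moves the number beyond the scatter.

These compounds share one set of atoms, so they leave open whether changing the atoms themselves would move the number. A carboxylic acid or an amine in place of a hydroxyl group, or a longer chain, could test that.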